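Pyridinyl swap on the opposite naphthylethyl epimer

The source may hold more compounds than are shown below. What is called first, only, known or untested is meant among the compounds shown, and "the series" means these compounds.

Measured so far in an ADME assay on MT4 cells (Homo sapiens) for cytotoxicity; a lower number here means that less compound is tolerated, a higher number that more compound is tolerated:
compound 1, `C[C@@H](NC(=O)[C@H](CCCNC(=N)N)NC(=O)c1ccc(CN(Cc2ccc(F)cc2)Cc2ccccn2)cc1)c1cccc2ccccc12`, 35000 nM
compound 2, `C[C@@H](NC(=O)[C@H](CCCNC(=N)N)NC(=O)c1ccc(CN(Cc2ccc(F)cc2)Cc2cccnc2)cc1)c1cccc2ccccc12`, 37000 nM
compound 3, `C[C@H](NC(=O)[C@H](CCCNC(=N)N)NC(=O)c1ccc(CN(Cc2ccc(F)cc2)Cc2ccccn2)cc1)c1cccc2ccccc12`, 11000 nM

The change of interest is pyridin-3-yl in place of pyridin-2-yl on a saturated chain carbon bound to an amine nitrogen. Made once, it gave a 1.1-fold higher number from compound 1 to compound 2 (0.02 log units; within the scatter). The cores on which it is now to be repeated differ as follows: the two compounds have the same atoms and bonds; at least one stereo element is drawn with a configuration in one of them and without one in the other: 1 of 3 stereo elements differ; a stereocentre at a saturated chain carbon is drawn R in compound 1 and S in compound 3. The step between those cores is a 3.2-fold lower number from compound 1 to compound 3 (0.50 log units; beyond the scatter), the one relevant observation being (the fact that one of compounds 1 and 3 is drawn with a defined configuration and the other without, at the place where they differ). Compound 3 therefore stands at the lowest of the three numbers in this assay, its nearest neighbour being compound 1.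

Compound 4, `C[C@H](NC(=O)[C@H](CCCNC(=N)N)NC(=O)c1ccc(CN(Cc2ccc(F)cc2)Cc2cccnc2)cc1)c1cccc2ccccc12`, is not yet measured. It differs from compound 3 by pyridin-3-yl in place of pyridin-2-yl on a saturated chain carbon bound to an amine nitrogen, which is the same change at the same place as that from compound 1 to compound 2. Since that step stayed within the scatter, the expectation is that compound 4 sits close to compound 3, with an estimated step of a 1.1-fold higher number from compound 3 to compound 4 (0.04 log units; within the scatter). The estimate for compound 4 in this assay is 12000 nM, expected to lie between 6000 nM and 24000 nM.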

Compound 4, half-maximal cytotoxic concentration: 41000 nM
Compound 4: middle estimate off by 3.4-fold (0.53 log units), on the low side; the measured number lies above the stated range.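

In this assay, the change from pyridin-2-yl to pyridin-3-yl did not carry over unchanged from the core of compound 1 to the core of compound 3, where the result was a 3.7-fold higher number from compound 3 to compound 4 (0.57 log units; beyond the scatter), and the two steps do not agree: the same change on two cores in this assay, a 1.1-fold higher number (0.02 log units; within the scatter) from compound 1 to compound 2 and a 3.7-fold higher number (0.57 log units; beyond the scatter) from compound 3 to compound 4, 3.5-fold (0.55 log units) apart, beyond the scatter of two such steps. The stereocentre step likewise depends on which group is present: it gives a 3.2-fold lower number from compound 1 to compound 3 (0.50 log units; beyond the scatter) with pyridin-2-yl but a 1.1-fold higher number from compound 2 to compound 4 (0.04 log units; within the scatter) with pyridin-3-yl, so the low number rests on compound 3 alone. These four compounds show that the size of this change depends on the configuration at that centre, but they do not show why, nor how the change would behave on any other core.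

As far as these compounds go, whether pyridin-4-yl at the same place gives a number like that of compound 3 or like that of compound 4 remains open on both epimers. Also open, from the compounds shown here alone, is whether this dependence on configuration appears in any read-out other than this assay.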